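A few compounds are considered here, and "the series" means these few. Any claim that something is new, unique, unknown or untested is made for them only; others in the source may bear on it.

Measured in a functional assay on the whole organism for agonist activity, with Mus musculus as the target; a higher number here means that more compound is needed for the effect, a lower number that less compound is needed:
- compound 1 `O=C1CCCN1CC#CCn1cnc2ccccc21`: > 100 mg/kg
- compound 2 `O=C1NCCN1CC#CCn1ccnc1`: 30 mg/kg

The entry for compound 1, > 100 mg/kg, is a limit of the assay and not a number.

Going by the values given here, compound 2, at 30 mg/kg, therefore holds the only numerical value so far in this assay. Among the compounds with values here, the two measured compounds differ in more than one place, and no single-change step between measured compounds is available to size the next one.

The next compound is compound 3 `Cc1cncn1CC#CCN1CCNC1=O`. It differs from compound 2 by one change, methyl in place of hydrogen on an aromatic carbon. With nothing measured for this kind of change, the expectation starts from compound 2 at 30 mg/kg. Within the data shown here, no step clearly beyond the scatter is expected in this assay, only a slight lean towards a higher dose, and a result reported only as a limit cannot be ruled out.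

The expected change is a 1.7-fold higher number from compound 2 to compound 3 (0.22 log units; within the scatter).

For compound 3 the estimated value is 50 mg/kg, with an expected range of 15 mg/kg to 150 mg/kg.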

Compound 3, dose for half-maximal effect: > 100 mg/kg
Compound 3 was reported as a limit (the forecaster's own chance of this, stated with the estimate: 25%); middle value at least 2.0-fold (0.30 log units) from the limit.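

Going by these compounds alone, this is the first single-change step, and in this assay it shows that one methyl in place of hydrogen on an aromatic carbon, on the five-membered aromatic ring with 2 nitrogen and next to the ring atom that bears a large group, is enough to give an at least 3.3-fold higher number from compound 2 to compound 3 (0.52 log units; beyond the scatter). Compound 3 gives > 100 mg/kg, which is a limit of the assay and not a number. The step therefore has a lower bound but no upper one, and its full size cannot be read because the values stop at the same ceiling: the limit of > 100 mg/kg in this assay, at which 2 of the 3 values shown sit.

On these data alone, whether this shift belongs to methyl itself or to any group at this carbon stays open; fluorine, chlorine, ethyl or hydroxymethyl in the same place would separate the two readings. As far as these compounds go, with a single step at one carbon, it also remains open whether methyl on another carbon of the same ring would shift the dose in the same way.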